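A few compounds are considered here, and "the series" means these few. Any claim that something is new, unique, unknown or untested is made for them only; others in the source may bear on it.

Measured in a functional assay on MGC-803 cells (Homo sapiens) for antiproliferative activity, read by MTT assay, with a stated time of 48 h; a higher number here means a weaker inhibitor, a lower number a stronger inhibitor:
- compound 1 `CCCCCCCCCCCCCCn1cc(COC[C@@H]2OC[C@H](N)[C@@H]2O)nn1`: 8210 nM
- compound 2 `CCCCCCCn1cc(COC[C@@H]2OC[C@H](N)[C@H]2O)nn1`: > 128000 nM, a limit of the assay
- compound 3 `CCCCCCCCCCCCn1cc(COC[C@@H]2OC[C@H](N)[C@H]2O)nn1`: 115000 nM

Compound 3 has the higher of the two numeric values, with compound 1 lower by a margin beyond the scatter. Compound 4 `CCCCCCCCCCCCCCn1cc(COC[C@@H]2OC[C@H](N)[C@H]2O)nn1` comes from compound 3 through (ethyl in place of hydrogen on a saturated chain carbon, ten or more bonds along the chain from an aromatic nitrogen). Within the data shown here, the only measured step bearing on this change is an at least 1.1-fold lower number from compound 2 to compound 3 (0.04 log units; that floor lies within the scatter), and its true size stays open given (the limit of > 128000 nM in this assay, at which 1 of the 3 values shown sits). A modest move towards a lower number is therefore expected, with compound 1 at 8210 nM taken as the lower reference. The expected change in this assay is a 3.3-fold lower number from compound 3 to compound 4 (0.52 log units; beyond the scatter). For compound 4 the estimate is 35000 nM, with an expected range of 8000 nM to 128000 nM.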

Compound 4, half-maximal inhibitory concentration: 8790 nM
Compound 4: the middle estimate sits 4.0-fold (0.60 log units) above what was measured; the measured number falls inside the stated range.
By their numbers in this assay, from the lowest: compounds 1 and 4 (each within the scatter of the next); then compound 3. At a limit, above all of these: compound 2.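

In this assay, ethyl in place of hydrogen on a saturated chain carbon, ten or more bonds along the chain from an aromatic nitrogen, gives a 13-fold lower number from compound 3 to compound 4 (1.12 log units; beyond the scatter), so lengthening this chain now has a measured size. Heptyl in place of hydrogen, seven bonds along the chain from an aromatic nitrogen, gives an at least 14-fold lower number from compound 2 to compound 4 (1.16 log units; beyond the scatter), a floor and not a full size, as one end of this step is a limit: the limit of > 128000 nM in this assay, at which 1 of the 4 values shown sits. Changing the configuration at one saturated ring carbon gives a 1.1-fold higher number from compound 1 to compound 4 (0.03 log units; within the scatter), which leaves the two stereoisomers inseparable here: the fact that compounds 1 and 4 differ only in the configuration as drawn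

Going by these compounds, whether a longer chain would lower the number further remains open. On these data alone, whether the two configurations would also stay within the scatter at a shorter chain remains open too.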